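A few compounds are considered here, and "the series" means these few. Any claim that something is new, unique, unknown or untested is made for them only; others in the source may bear on it.

Measured so far:
Compound 1 `CN1CCC(n2nnc3c2CCC(c2nc(-c4ccc(F)cc4)no2)C3)CC1` gives 3980 nM in a functional assay on U2OS cells for positive allosteric modulation of metabotropic glutamate receptor 5 (Homo sapiens), read by calcium flux, in the presence of a further agent that is not named here; a higher number here means that more compound is needed for the effect, a lower number that less compound is needed.
Compound 2 `CC(C)n1nnc2c1CCC(c1nc(-c3ccc(F)cc3)no1)C2` gives 398 nM in this assay.

Within the data shown here, of the two numbers, compound 2 holds the lower one, meaning less of it is needed; the only other number belongs to compound 1, and the step between them is a 10-fold lower number from compound 1 to compound 2 (1.00 log units; beyond the scatter), which swaps 1-methylpiperidin-4-yl for isopropyl on an aromatic nitrogen.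

Compound 3 `CC(C)(C)Cn1nnc2c1CCC(c1nc(-c3ccc(F)cc3)no1)C2` keeps the shared core and differs from compound 2 in one place: neopentyl in place of isopropyl on an aromatic nitrogen. Among the measured compounds shown here, only one measured step exists here, and it concerns a group with a ring giving way to a small chain. For the measured compounds named here, for a chain giving way to a somewhat longer chain at the same aromatic nitrogen, no comparable step has been measured, so the nearest guide is that compound 2 already sits at the lower end of what is known.

Compound 3 is therefore expected to give about 500 nM, within a range from 150 nM to 1600 nM.
This estimate corresponds to a 1.3-fold higher number from compound 2 to compound 3 (0.10 log units; within the scatter), a change expected to stay within the usual scatter.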

Compound 3, half-maximal effective concentration: 31.6 nM
Compound 3: the middle estimate sits 16-fold (1.20 log units) above what was measured; measured number below the stated range.
By their numbers in this assay, from the lowest: compound 3; then compound 2; then compound 1.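

In this assay, neopentyl in place of isopropyl gives a 13-fold lower number from compound 2 to compound 3 (1.10 log units; beyond the scatter), so the number at this aromatic nitrogen still moves well beyond the scatter when one ringless carbon group replaces another, which the earlier step, involving a ring, could not show. Neopentyl in place of 1-methylpiperidin-4-yl gives a 130-fold lower number from compound 1 to compound 3 (2.10 log units; beyond the scatter), the widest step at this position among the compounds shown. Nothing available explains why the number falls with either change.

The compounds shown do not separate the branched shape of neopentyl from its count of 5 heavy atoms: an unbranched pentyl chain or a tert-butyl group at the same nitrogen would speak to that. On these data alone, whether a hydroxyl group or an amine on such a chain would keep the low number also remains open.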